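Adding a Hydroxyl Group to the Ring of Compound 1

The source may hold more compounds than are shown below. What is called first, only, known or untested is meant among the compounds shown, and "the series" means these compounds.

Compound 1 `CSc1ccc(CSc2nc(-c3ccc(F)cc3)c(-c3ccncc3)[nH]2)cc1` and compound 2 `Fc1ccc(-c2[nH]c(SCCc3ccccc3)nc2-c2ccncc2)cc1` share one core and differ only in the chain attached to the sulfur. In a functional assay (Homo sapiens) for inhibition (on this read-out higher numbers stand for weaker inhibition and lower numbers for stronger inhibition), compound 1 gives 670 nM, the highest of the two plain numbers, while compound 2 gives 640 nM, which lies within the usual scatter of the number for compound 1. Compound 3 `N#CCSc1nc(-c2ccncc2)c(-c2ccc(F)cc2)[nH]1` gives in this assay no number but a limit, < 100 nM, (the limit of < 100 nM in this assay, at which 1 of the 3 values shown sits). Going by the values given here, the one measured step, an at least 6.4-fold lower number from compound 2 to compound 3 (0.80 log units; beyond the scatter), concerns a change unlike the one followed here. Compound 4 `CSc1ccc(O)c(CSc2nc(-c3ccc(F)cc3)c(-c3ccncc3)[nH]2)c1` differs from compound 1 by 2-hydroxy-5-(methylsulfanyl)phenyl in place of 4-(methylsulfanyl)phenyl on a saturated chain carbon bound to a sulfur. Among the compounds with values here, no measured step bears on this change, so no shift beyond the scatter is expected. The expected step is a 1.2-fold lower number from compound 1 to compound 4 (0.09 log units; within the scatter). Compound 4 is estimated at 550 nM, ranging from 150 nM to 2000 nM.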

Compound 4, half-maximal inhibitory concentration: 740 nM
Beside the measured number, compound 4's estimate is 1.3-fold (0.13 log units) below it; measured number inside the range.
By their numbers in this assay, from the lowest: compounds 2, 1 and 4 (each within the scatter of the next). At a limit, below all of these: compound 3.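

In this assay, going by these compounds alone, the change to 2-hydroxy-5-(methylsulfanyl)phenyl gives a 1.1-fold higher number from compound 1 to compound 4 (0.04 log units; within the scatter), the first measured step on this ring rather than on the chain as a whole. The added hydroxyl group, with its extra hydrogen-bond donor, therefore brings no change that can be told from the scatter. Nothing shown here accounts for this outcome. Going by these compounds, whether a methoxy group, an amine or a carboxylic acid in place of this hydroxyl would also leave the number within the scatter stays open.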